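The source may hold more compounds than are shown below. What is called first, only, known or untested is meant among the compounds shown, and "the series" means these compounds.

Measured so far:
compound 1, `O=C(C1CCC(F)(F)CC1)N1CC(c2nc(-c3cccc(Cl)c3)no2)C1`: > 10000 nM
compound 2, `O=C(c1ccc(Cl)cc1)N1CC(c2nc(-c3cccc(F)c3)no2)C1`: > 10000 nM

Compound 1, `O=C(C1CCC(F)(F)CC1)N1CC(c2nc(-c3cccc(Cl)c3)no2)C1`, was tested in an assay on HEK293 cells for negative allosteric modulation of metabotropic glutamate receptor 5 (Homo sapiens), read by FLIPR; a higher number here means a weaker inhibitor, a lower number a stronger inhibitor. There compound 1 gives > 10000 nM, which is a limit of the assay and not a number. Compound 2, `O=C(c1ccc(Cl)cc1)N1CC(c2nc(-c3cccc(F)c3)no2)C1`, gives > 10000 nM in this assay, again a limit. Among the compounds with values here, both values therefore rest at the limit of > 10000 nM in this assay, at which 2 of the 2 values shown sit, and no step between measured compounds can be read from them.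

Compound 3, `CC1CN(C(=O)N2CC(c3nc(-c4cccc(Cl)c4)no3)C2)CC(C)O1`, is not yet measured. It differs from compound 1 by 2,6-dimethylmorpholin-4-yl in place of 4,4-difluorocyclohexyl on a carbonyl carbon. With nothing but two limits to go on, the step from compound 1 to compound 3 cannot be anchored by a shown change, and the expectation is that the step that the limit leaves unreadable from compound 1 to compound 3 will be none beyond the scatter. Because compound 1 sits at the limit of > 10000 nM in this assay, at which 2 of the 2 values shown sit, compound 3 is estimated at 15000 nM, with a range from 3000 nM to 60000 nM.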

Compound 3, half-maximal inhibitory concentration: 990 nM
Compound 3: the middle estimate sits 15-fold (1.18 log units) above what was measured; measured number below the stated range.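

In this assay compound 1 gives > 10000 nM, a limit of the assay and not a number. Within the data shown here, with 2,6-dimethylmorpholin-4-yl in place of 4,4-difluorocyclohexyl on a carbonyl carbon, the result is an at least 10-fold lower number from compound 1 to compound 3 (1.00 log units; beyond the scatter), which shows that a change at this one place can bring the series into the measurable range, something the earlier compounds did not show. The two groups have the same heavy-atom count but differ in their atoms, and compound 3 alone has left the limit: the limit of > 10000 nM in this assay, at which 2 of the 3 values shown sit.

Going by these compounds, the full size of the step stays unknown, as it starts from a limit. Also open, on these data alone, is whether it belongs to the ring oxygen, the ring nitrogen or the two methyl groups, which an unsubstituted morpholine or a piperidine at the same place would help to separate.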